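One Added Methyl on the Amine Chain

A few compounds are considered here, and "the series" means these few. Any claim that something is new, unique, unknown or untested is made for them only; others in the source may bear on it.

Of the compounds shown here, three with the same core have been tested in a functional assay on MCF7 cells (Homo sapiens) for antiproliferative activity; on this read-out higher numbers stand for weaker inhibition and lower numbers for stronger inhibition. Compound 1 `CC(C)=CCc1cc(C(=O)Nc2cc3ccc(OCCC4CCCCN4)c(C)c3oc2=O)ccc1O` gives 710 nM, compound 2 `CC(C)=CCc1cc(C(=O)Nc2cc3ccc(OCC4CCCN(C)C4)c(C)c3oc2=O)ccc1O` gives 2640 nM, and compound 3 `CCN(C)CCCOc1ccc2cc(NC(=O)c3ccc(O)c(CC=C(C)C)c3)c(=O)oc2c1C` gives 2190 nM. That places compound 3 level with compound 2 and weaker than compound 1.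

Compound 4 `CCN(CC)CCCOc1ccc2cc(NC(=O)c3ccc(O)c(CC=C(C)C)c3)c(=O)oc2c1C` differs from compound 3 by one small edit: methyl in place of hydrogen on a saturated chain carbon bound to an amine nitrogen. This is methyl in place of hydrogen on a saturated chain carbon bound to an amine nitrogen, which turns ethyl(methyl)amino into diethylamino.

For the measured compounds named here, no measured step makes this exact change. The nearest evidence is a larger rebuilding of the amine side chain, which shows a 1.2-fold lower number from compound 2 to compound 3 (0.08 log units; within the scatter). Going by the values given here, only the steps leaving compound 1 exceed the scatter, at a 3.7-fold higher number from compound 1 to compound 2 (0.57 log units; beyond the scatter) and a 3.1-fold higher number from compound 1 to compound 3 (0.49 log units; beyond the scatter), and both remove its piperidin-2-yl unit, which the present edit leaves untouched.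

In this assay the estimated step is a 1.1-fold lower number from compound 3 to compound 4 (0.04 log units; within the scatter), so nothing beyond the scatter is expected. Compound 4 is expected at 2000 nM, within an estimated range of 900 nM to 4500 nM.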

Compound 4, half-maximal inhibitory concentration: 6390 nM
Compound 4: the middle estimate sits 3.2-fold (0.50 log units) below what was measured, outside the stated range (above it).
By their numbers in this assay, from the lowest: compound 1; then compounds 3 and 2 (each within the scatter of the next); then compound 4.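

In this assay the amine end of this chain proves sensitive to a very small edit: methyl in place of hydrogen, turning ethyl(methyl)amino into diethylamino, gives a 2.9-fold higher number from compound 3 to compound 4 (0.47 log units; beyond the scatter). That costs more than the larger rebuilding of the chain appeared to, at a 1.2-fold lower number from compound 2 to compound 3 (0.08 log units; within the scatter). Compound 4 also separates from the other chain compound, with a 2.4-fold higher number from compound 2 to compound 4 (0.38 log units; beyond the scatter) beyond the scatter, so it no longer sits level with that group. The widest gap in the set is now a 9.0-fold higher number from compound 1 to compound 4 (0.95 log units; beyond the scatter) and makes compound 4 the weakest of the four.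

Nothing available here explains why one added methyl matters this much. From the compounds shown here alone, whether the trend continues in the other direction stays open, since dimethylamino on the same chain would show if a smaller amine gives a lower number.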